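This account rests on a few compounds, and the source may have more. Where it says the series, first, only, none or still open, it means among the compounds named here.

Working notes on a small series of compounds that share one core and carry methoxy groups on two aromatic rings. In a functional assay on MCF7 cells (Homo sapiens) for cytotoxicity, read by MTT assay, with a stated time of 72 h (on this read-out higher numbers stand for weaker inhibition and lower numbers for stronger inhibition), compound 1 (`COc1cccc(/C=C2\CCC/C(=C\c3cc(OC)c(OC)c(OC)c3)C2=O)c1OC`) gives 1400 nM, compound 2 (`COc1ccc(/C=C2\CCC/C(=C\c3ccc(OC)c(OC)c3)C2=O)cc1OC`) gives 13500 nM and compound 3 (`COc1cc(/C=C2\CCC/C(=C\c3ccc(OC)c(OC)c3)C2=O)cc(OC)c1`) gives 3900 nM. Compound 3 holds the middle place of the three, with a number lower than that of compound 2 and higher than that of compound 1, and both gaps lie beyond the scatter.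

The next compound is compound 4 (`COc1ccc(/C=C2\CCC/C(=C\c3cc(OC)c(OC)c(OC)c3)C2=O)cc1OC`), which differs from compound 3 by methoxy in place of hydrogen on an aromatic carbon, ortho to two methoxy groups and para to a large group. Among the compounds with values here, no measured pair isolates a single change, so the guidance is indirect. One aromatic ring of compound 4 matches a ring of compound 1, which gives 1400 nM. Its other ring matches a ring of compound 3, which gives 3900 nM. A value between these two is therefore expected in this assay. The expected change is a 1.6-fold lower number from compound 3 to compound 4 (0.21 log units; within the scatter), a modest estimated move towards stronger inhibition. For compound 4 the estimated value is 2400 nM, with an expected range of 800 nM to 7000 nM.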

Compound 4, half-maximal inhibitory concentration: 1600 nM
The estimate for compound 4 lay 1.5-fold (0.18 log units) above the measured number; low and high end bracket the measured number.
By their numbers in this assay, from the lowest: compounds 1 and 4 (each within the scatter of the next); then compound 3; then compound 2.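

In this assay, within the data shown here, methoxy in place of hydrogen on an aromatic carbon, ortho to two methoxy groups and para to a large group, gives a 2.4-fold lower number from compound 3 to compound 4 (0.39 log units; beyond the scatter) and is the first single change that can be read. The same kind of replacement starting from compound 2 gives an 8.4-fold lower number from compound 2 to compound 4 (0.93 log units; beyond the scatter), so two separate starting points now move towards stronger inhibition when a methoxy is added, and neither step goes against this. The exchange of ring gives a 1.1-fold higher number from compound 1 to compound 4 (0.06 log units; within the scatter), which leaves 3,4-dimethoxyphenyl and 2,3-dimethoxyphenyl on that double-bonded chain carbon indistinguishable on this read-out while the other ring stays as it is.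

Why the added methoxy goes with stronger inhibition stays open, as nothing at hand bears on the cause. Also open, on these data alone, is whether methoxy itself matters at that aromatic carbon or whether another group, such as hydroxyl, fluorine or an amine, would give a similar step in this assay on the shared core.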